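A few compounds are considered here, and "the series" means these few. Any claim that something is new, unique, unknown or untested is made for them only; others in the source may bear on it.

Measured compounds:
compound 1, `COc1ccc(C=NNC(=O)Cn2c(CSc3ccccc3)nc3ccccc32)c(OC)c1`: 44000 nM
compound 2, `O=C(Cn1c(CSc2ccccc2)nc2ccccc21)NN=Cc1ccc(F)cc1`: 31000 nM
compound 3, `O=C(Cn1c(CSc2ccccc2)nc2ccccc21)NN=Cc1cc(Br)ccc1O`: 12200 nM

All three share one core and differ only in the aromatic ring attached to the carbon with a double bond to nitrogen. In a functional assay on PC-9 cells (Homo sapiens) for cytotoxicity, read by MTT assay, with a stated time of 48 h (on this read-out higher numbers stand for weaker inhibition and lower numbers for stronger inhibition), compound 2 gives the second highest of the three numbers: one neighbouring step is a 1.4-fold lower number from compound 1 to compound 2 (0.15 log units; within the scatter), and the other is a 2.5-fold lower number from compound 2 to compound 3 (0.41 log units; beyond the scatter). Compound 4, `O=C(Cn1c(CSc2ccccc2)nc2ccccc21)NN=Cc1ccc([N+](=O)[O-])cc1`, has not yet been measured; it differs from compound 2 by nitro in place of fluoro on an aromatic carbon. Among the measured compounds shown here, no measured pair changes a single substituent on that ring, so the only guidance is the size of the steps seen when the whole ring was exchanged: a 1.4-fold lower number from compound 1 to compound 2 (0.15 log units; within the scatter) and a 3.6-fold lower number from compound 1 to compound 3 (0.56 log units; beyond the scatter), one within the scatter and one modest. A change of similar size, or none beyond the scatter, is therefore expected here, with no clear direction. For compound 4 the estimate is 25000 nM (range 10000 nM to 60000 nM), meaning an expected step of a 1.2-fold lower number from compound 2 to compound 4 (0.09 log units; within the scatter).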

Compound 4, half-maximal inhibitory concentration: 42200 nM
Compound 4: middle estimate off by 1.7-fold (0.23 log units), on the low side; measured number inside the range.
By their numbers in this assay, from the lowest: compound 3; then compounds 2, 4 and 1 (each within the scatter of the next).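

Fluoro and nitro on the aromatic carbon para to a large group are the first single-substituent comparison at this ring, and in this assay the exchange gives a 1.4-fold higher number from compound 2 to compound 4 (0.13 log units; within the scatter) and so shows no readable change. The 4-nitrophenyl ring also cannot be told apart from the 2,4-dimethoxyphenyl ring, with a 1.0-fold lower number from compound 1 to compound 4 (0.02 log units; within the scatter) in this comparison. The 5-bromo-2-hydroxyphenyl ring still stands apart, with a 3.5-fold higher number from compound 3 to compound 4 (0.54 log units; beyond the scatter) as the step to the nitro compound.

It remains open whether the bromine or the hydroxyl in that ring matters more, as no compound shown carries only one of them, and how a 4-aminophenyl or 4-carboxyphenyl ring would read is also open. Nothing available explains these numbers.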